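A few compounds are considered here, and "the series" means these few. Any claim that something is new, unique, unknown or untested is made for them only; others in the source may bear on it.

The account opens with two measured compounds that share one core. Compound 1 `O=C1CSC(c2c(Cl)cccc2Cl)N1CCN1CCCCC1` was tested in an ADME assay on Vero cells (Chlorocebus sabaeus) for cytotoxicity, read by neutral red uptake, tested at 49 ug/mL (a lower number here means a stronger effect, a higher number a weaker effect of the compound at the concentration tested), where compound 1 gives 100%. Compound 2 `COc1ccc(C2SCC(=O)N2CCN2CCCCC2)cc1` was tested in the same way, and in this assay compound 2 gives 100%. Among the compounds with values here, on these numbers compound 2 stands level with compound 1 at the digits reported; no step between the two is counted, and the two values lie within the usual scatter of each other, so nothing is said here of an order between them.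

The piece now follows the move from compound 2 to compound 3 `O=C1CSC(c2ccc([N+](=O)[O-])cc2)N1CCN1CCCCC1`. The change is nitro in place of methoxy on an aromatic carbon. Within the data shown here, with both measured compounds sitting at the same reading, and with no counted step between them to lean on, the expectation for compound 3 is a step of a number 2 percentage points lower from compound 2 to compound 3 (within the scatter) in this assay, that is, none beyond the scatter. In this assay compound 3 is therefore estimated at 98%, with a range from 85% to 105%.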

Compound 3, a percentage reported as activity, at one concentration (the size of the read-out at that concentration, not a potency): 100%
For compound 3 the middle estimate is 2 percentage points below the measured one, within the range that was stated.
By their numbers in this assay, from the lowest: compounds 1, 2 and 3 (each within the scatter of the next).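

Nitro in place of methoxy on an aromatic carbon, para to a large group, gives the first counted step of the account, and in this assay that step reads no change at the digits printed from compound 2 to compound 3 (within the scatter). The earlier compounds shown here offered no such single-place comparison, whereas this pair shows that, on this six-membered aromatic ring of carbon only, two groups that differ in their atoms and in their count of hydrogen-bond acceptors give readings that stay within the scatter of each other at the one concentration tested. Nothing independent of this reading bears on why the two compounds stand level, so the result remains an observation about this one pair.

The compounds shown leave open whether the same level would hold with a different kind of group at this aromatic carbon, such as an amine or a carboxylic acid. They also leave open how any of these compounds would read in this assay at another concentration, since a single concentration gives the size of the read-out there and not a potency.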